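Swapping the amine at the carbonyl of a stilbene-derived series

This account rests on a few compounds, and the source may have more. Where it says the series, first, only, none or still open, it means among the compounds named here.

Measured compounds in a functional assay on A549 cells (Homo sapiens) for inhibition, read by MTT assay, with a stated time of 48 h; on this read-out higher numbers stand for weaker inhibition and lower numbers for stronger inhibition:
compound 1 `COc1ccc(/C=C/c2cc(OC)cc(OC)c2/C=C/C(=O)NC2CC2)cc1`: 8810 nM
compound 2 `COc1ccc(/C=C/c2cc(OC)cc(OC)c2/C=C/C(=O)N2CCCCC2)cc1`: 10600 nM
compound 3 `CCNC(=O)/C=C/c1c(/C=C/c2ccc(OC)cc2)cc(OC)cc1OC`: 7860 nM

Compound 1 stands second highest of the three numbers, with compound 3 nearest and compound 2 furthest; all three lie within the scatter of one another. Compound 4 `CCCCCN(CCCCC)C(=O)/C=C/c1c(/C=C/c2ccc(OC)cc2)cc(OC)cc1OC` differs from compound 1 in one place: dipentylamino in place of cyclopropylamino on a carbonyl carbon. Two earlier steps changed the group on the same carbonyl carbon, a 1.2-fold higher number from compound 1 to compound 2 (0.08 log units; within the scatter) and a 1.3-fold lower number from compound 2 to compound 3 (0.13 log units; within the scatter), and neither moved the number beyond the scatter; the other, a 1.1-fold lower number from compound 1 to compound 3 (0.05 log units; within the scatter), was equally flat. From this, no step beyond the scatter is expected for compound 4, so a 1.1-fold higher number from compound 1 to compound 4 (0.06 log units; within the scatter) is the estimated outcome. Compound 4 is therefore expected to give about 10000 nM, estimated between 4000 nM and 25000 nM.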

Compound 4, half-maximal inhibitory concentration: 7490 nM
Compound 4: middle estimate off by 1.3-fold (0.13 log units), on the high side; the measured number falls inside the stated range.
By their numbers in this assay, from the lowest: compounds 4, 3, 1 and 2 (each within the scatter of the next).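

In this assay, dipentylamino, with 11 heavy atoms and no ring, replaces the 4 heavy atoms of cyclopropylamino on the carbonyl carbon and gives a 1.2-fold lower number from compound 1 to compound 4 (0.07 log units; within the scatter), so this much larger open chain still leaves the number within the scatter. The comparisons with the other two amides agree, giving a 1.0-fold lower number from compound 3 to compound 4 (0.02 log units; within the scatter) and a 1.4-fold lower number from compound 2 to compound 4 (0.15 log units; within the scatter), and no change at this position among the four compounds moves the number beyond the scatter. Nothing available explains this flatness. The compounds shown leave open whether a carboxylic acid or a basic dimethylaminoethyl chain on the amide nitrogen would shift the number beyond the scatter.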